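Aryl swap at the saturated carbon of the shared core

The source may report more compounds than this note shows. Statements on the series, on what has been measured and on what is new or still open speak of the compounds shown alone.

Two analogues of the shared core carry different aryl groups on the saturated ring carbon. Compound 1 `CC(=O)N1N=C(c2ccc3ccccc3c2)OC1c1ccccc1Cl` bears a 2-chlorophenyl there; in a functional assay on B16-F10 cells (Mus musculus) for antiproliferative activity, read by MTT assay, with a stated time of 48 h (a higher number here means a weaker inhibitor, a lower number a stronger inhibitor), compound 1 gives 4.93 ug/mL. Compound 2 `CC(=O)N1N=C(c2ccc3ccccc3c2)OC1c1ccc(F)cc1` bears a 4-fluorophenyl; in this assay compound 2 gives 4.65 ug/mL. Among the measured compounds shown here, the only measured step, a 1.1-fold lower number from compound 1 to compound 2 (0.03 log units; within the scatter), is within the scatter, so the two aryl groups are indistinguishable on these numbers. Compound 2 shows the lowest of the two values, yet its nearest neighbour, compound 1, sits within the scatter of it, so no ranking is claimed.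

Compound 3 `CC(=O)N1N=C(c2ccc3ccccc3c2)OC1c1ccsc1` is the next member. It differs from compound 2 in one place: thiophen-3-yl in place of 4-fluorophenyl on a saturated ring carbon. For the measured compounds named here, the one step that bears on this change is the earlier aryl swap, and because a 1.1-fold lower number from compound 1 to compound 2 (0.03 log units; within the scatter) lay within the scatter, no movement beyond the scatter is expected in this assay for compound 3, a 1.1-fold higher number from compound 2 to compound 3 (0.03 log units; within the scatter). Compound 3 is thus estimated at 5 ug/mL, with a range from 2.5 ug/mL to 10 ug/mL.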

Compound 3, half-maximal inhibitory concentration: 8.56 ug/mL
For compound 3 the middle estimate is 1.7-fold (0.23 log units) below the measured one, and the stated range covers the measured number.
By their numbers in this assay, from the lowest: compounds 2, 1 and 3 (each within the scatter of the next).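

In this assay the saturated ring carbon now carries a five-membered aromatic ring with 1 hetero atom as well as the substituted six-membered aromatic rings of carbon only, and the steps are a 1.8-fold higher number from compound 2 to compound 3 (0.27 log units; within the scatter) and a 1.7-fold higher number from compound 1 to compound 3 (0.24 log units; within the scatter). Both steps stay within the scatter, so thiophen-3-yl cannot be told apart from 4-fluorophenyl or 2-chlorophenyl on these numbers, and the change in ring size and ring atoms at this position brings no resolved difference across the three compounds. Nothing measured here offers an explanation for these numbers.

As far as these compounds go, all three compounds keep an aromatic ring at this position, so it remains open how the assay responds to a saturated group such as cyclohexyl, or to an aryl ring carrying an amine or a carboxylic acid. The acetyl group is also the same throughout, which leaves open whether the same reading would hold with a longer acyl chain in its place.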